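Cytotoxicity Outlook for a 4-Ethylphenyl Amide Analogue

The source may hold more compounds than are shown below. What is called first, only, known or untested is meant among the compounds shown, and "the series" means these compounds.

Compound 2 `CCCCCC(=O)Nc1cc2nc(C3CCCCC3)[nH]c2cc1N(C)C` carries a pentyl group on its carbonyl carbon. In an ADME assay on Vero cells (Chlorocebus sabaeus) for cytotoxicity, read by resazurin assay, with a stated time of 3 days (on this read-out lower numbers stand for stronger inhibition and higher numbers for weaker inhibition), compound 2 gives > 100 ug/mL, which is a limit of the assay rather than a number. Its counterpart compound 1 `CN(C)c1cc2[nH]c(C3CCCCC3)nc2cc1NC(=O)c1ccc(Br)cc1` bears a 4-bromophenyl group at the same place. In this assay compound 1 gives > 100 ug/mL, again a limit of the assay. The step that the two limits leave unreadable from compound 1 to compound 2 therefore cannot be read, and the limit of > 100 ug/mL in this assay, at which 2 of the 2 values shown sit, is all that the two measurements leave. Compound 3 `CCc1ccc(C(=O)Nc2cc3nc(C4CCCCC4)[nH]c3cc2N(C)C)cc1` is the next member: 4-ethylphenyl in place of pentyl on a carbonyl carbon. Within the data shown here, only that unreadable step bears on this change, and it gives no size. Because the limit of > 100 ug/mL in this assay, at which 2 of the 2 values shown sit, applies to both measured compounds, compound 3 is expected to show no step beyond the scatter, a number no higher from compound 2 to compound 3 (the limit leaves the size open). The estimate for compound 3 in this assay is 100 ug/mL, with a range from 40 ug/mL to 250 ug/mL.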

Compound 3, half-maximal inhibitory concentration: > 100 ug/mL
Compound 3 was reported as a limit; the forecaster's own chance of this, stated with the estimate: 80%; the middle value lies on the limit itself.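

In this assay compound 3 gives > 100 ug/mL, again a limit of the assay, so the steps among compound 1, compound 2 and compound 3 cannot be read. Whether the 4-bromophenyl, pentyl and 4-ethylphenyl groups differ at all in this read-out stays open: the limit of > 100 ug/mL in this assay, at which 3 of the 3 values shown sit.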